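This account rests on a few compounds, and the source may have more. Where it says the series, first, only, none or still open, it means among the compounds named here.

Measured compounds in a functional assay on H266 cells (Homo sapiens) for cytotoxicity, read by resazurin assay, with a stated time of 72 h; a lower number here means a stronger inhibitor, a higher number a weaker inhibitor:

compound 1 `O=C(/C=C/c1ccc(OCCCCCO[N+](=O)[O-])c(O)c1)OCCCCCO[N+](=O)[O-]` — > 50000 nM (a limit of the assay, not a number)
compound 2 `O=C(/C=C/c1ccc(OCCCCCCO[N+](=O)[O-])c(O)c1)OCCCCCCO[N+](=O)[O-]` — > 50000 nM (a limit of the assay, not a number)
compound 3 `COc1cc(/C=C/C(=O)OCCCCCO[N+](=O)[O-])ccc1OCCCCCO[N+](=O)[O-]` — > 50000 nM (a limit of the assay, not a number)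

Compound 1 in this assay reaches only the limit > 50000 nM. Compound 2 likewise gives only the limit > 50000 nM. Compound 3 gives the limit > 50000 nM. All three values sit at the same limit, (the limit of > 50000 nM in this assay, at which 3 of the 3 values shown sit), so none can be ranked against another.

The change from compound 1 to compound 3 is methyl in place of hydrogen on an oxygen on an aromatic ring; its step that the two limits leave unreadable from compound 1 to compound 3 cannot be read, as both ends are limits. The difference between the cores of compound 1 and compound 2 is not broken down here.

Compound 4 `COc1cc(/C=C/C(=O)OCCCCCCO[N+](=O)[O-])ccc1OCCCCCCO[N+](=O)[O-]` is not yet measured. It differs from compound 2 by methyl in place of hydrogen on an oxygen on an aromatic ring, the same change as from compound 1 to compound 3, at a place described in the same words.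

The step from compound 2 to compound 4 in this assay is expected to be a step that the limit leaves unreadable from compound 2 to compound 4, resting on compound 2 at > 50000 nM and compound 3 at > 50000 nM, both limits. Compound 4 is accordingly estimated at 80000 nM, between 40000 nM and 200000 nM, most likely reported again only as a limit.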

Compound 4, half-maximal inhibitory concentration: > 50000 nM
Compound 4 ended at the assay's limit; the forecaster's own chance of this, stated with the estimate: 85%; the middle value lies beyond the limit too.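

Compound 2 and compound 4 both end at a limit of the assay in this assay, so the hydroxy to methoxy change between them gives no readable step, and no new step can be read: the limit of > 50000 nM in this assay, at which 4 of the 4 values shown sit.

The compounds shown leave open how far past that limit each one lies, and whether this change alters cytotoxicity at all.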